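Fluorine on the Benzoyl Ring and Tolerated Concentration

The source may report more compounds than this note shows. Statements on the series, on what has been measured and on what is new or still open speak of the compounds shown alone.

Compound 1 `O=C(CSc1nc(Cc2c(Cl)cccc2Cl)cc(=O)[nH]1)c1ccccc1` carries a benzoyl group attached through a thioether-linked methylene to its core. In an ADME assay on MT4 cells (Homo sapiens) for cytotoxicity, read by MTT assay (a higher number here means that more compound is tolerated, a lower number that less compound is tolerated), compound 1 gives > 12000 nM, which is a limit of the assay and not a number. Compound 2 `O=C(CSc1nc(Cc2c(Cl)cccc2Cl)cc(=O)[nH]1)c1ccc(F)cc1` differs from compound 1 only by fluoro in place of hydrogen on an aromatic carbon. In this assay compound 2 gives > 59000 nM, again a limit rather than a measured number. The change therefore produced a step that the two limits leave unreadable from compound 1 to compound 2.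

Compound 3 `CC(C)c1c(Cc2c(F)cccc2Cl)nc(SCC(=O)c2ccccc2)[nH]c1=O` has a different core; how it differs from compound 1 is not broken down here. In this assay compound 3 gives > 12000 nM, which is a limit only. Compound 4 `CC(C)c1c(Cc2c(F)cccc2Cl)nc(SCC(=O)c2ccc(F)cc2)[nH]c1=O` differs from compound 3 by fluoro in place of hydrogen on an aromatic carbon, the same change seen between compound 1 and compound 2, at the same place on the ring.

Among the compounds with values here, because the limit of > 12000 nM in this assay, at which 2 of the 3 values shown sit, and the limit of > 59000 nM in this assay, at which 1 of the 3 values shown sits, are the only readings available, the step from compound 3 to compound 4 is expected to be a step that the limit leaves unreadable from compound 3 to compound 4, meaning no readable change in tolerated concentration. Compound 4 is accordingly expected to give about 30000 nM, with an estimated range from 12000 nM to 100000 nM, most likely reported as a limit.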

Compound 4, half-maximal cytotoxic concentration: > 56000 nM
Compound 4: no number, only a limit; the forecaster's own chance of this, stated with the estimate: 85%; middle value at least 1.8-fold (0.27 log units) away from the limit.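

Compound 3 and compound 4 are both reported in this assay only as limits of the assay and not as numbers, so the step between them cannot be read. The compounds shown leave open the concentration at which any of the four becomes cytotoxic, and whether fluoro in place of hydrogen on an aromatic carbon changes it at all.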